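From nitrile to tetrazole on a shared core

This account rests on a few compounds, and the source may have more. Where it says the series, first, only, none or still open, it means among the compounds named here.

In a functional assay for inhibition, with Homo sapiens as the target (a higher number here means a weaker inhibitor, a lower number a stronger inhibitor), compound 1 `CC(O)c1cc(-c2ccccc2)c2ccc(OCc3cccc(C4(O)CCOCC4)c3)cc2c1` gives 28 nM and compound 2 `N#Cc1cc(-c2ccccc2)c2ccc(OCc3cccc(C4(O)CCOCC4)c3)cc2c1` gives 3 nM, so compound 2 holds the lower of the two numbers, and the gap between them lies beyond the scatter. Compound 3 `OC1(c2cccc(COc3ccc4c(-c5ccccc5)cc(-c5nn[nH]n5)cc4c3)c2)CCOCC1` keeps the core of compound 2 but carries 2H-tetrazol-5-yl in place of cyano on an aromatic carbon.

Among the measured compounds shown here, only one measured step bears on this change, and it involves the same aromatic carbon: a 9.3-fold lower number from compound 1 to compound 2 (0.97 log units; beyond the scatter). That modest step shows that this assay responds to the group placed there, with cyano giving the lower number of the two groups tested. For the measured compounds named here, no measured compound carries a tetrazole, so the evidence is thin. Replacing the cyano of compound 2 is nevertheless expected to raise the number by about as much as that one measured step, although a smaller change remains possible. The expected step is an 8.3-fold higher number from compound 2 to compound 3 (0.92 log units; beyond the scatter). Compound 3 is estimated at 25 nM, within an expected range from 5 nM to 120 nM.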

Compound 3, half-maximal inhibitory concentration: > 700 nM
Compound 3: only a limit was reported; the forecaster's own chance of this, stated with the estimate: 5%; middle value at least 28-fold (1.44 log units) from the limit.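

The response at this aromatic carbon is far larger than the earlier pair suggested, and 2H-tetrazol-5-yl is not tolerated as cyano or 1-hydroxyethyl are: the change gives an at least 230-fold higher number from compound 2 to compound 3 (2.36 log units; beyond the scatter). Against the weaker of the two earlier compounds the loss is still large, with an at least 25-fold higher number from compound 1 to compound 3 (1.39 log units; beyond the scatter), so among the three groups shown the order in this assay is cyano, then 1-hydroxyethyl, then 2H-tetrazol-5-yl, each gap beyond the scatter. The figure for compound 3 is a limit and not a number, so both steps give only the least size of the loss: the limit of > 700 nM in this assay, at which 1 of the 3 values shown sits.

As far as these compounds go, how far compound 3 lies past that limit stays open, and with three groups at one position the data cannot say which feature of 2H-tetrazol-5-yl goes with the loss, whether its five-membered aromatic ring, its size or its hydrogen-bond donor. From the compounds shown here alone, a carboxylic acid, a primary amide or a small ring such as oxazole on the same aromatic carbon would help to separate these, and whether any group gives a lower number than cyano also remains unknown.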